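The compounds below may be only part of what the source reports. "The series", "measured", "known", "first", "only" and "open" are said of these compounds alone.

Three compounds have been measured in an assay on CHO cells for displacement of a labelled ligand from melatonin receptor type 1B (Homo sapiens), read by scintillation counting, with a stated time of 60 min; on this read-out higher numbers stand for weaker inhibition and lower numbers for stronger inhibition:

compound 1 `COc1ccc(O)c(CCCNC(C)=O)c1` gives 46.2 nM
compound 2 `CCOc1ccc(OC)cc1CCCNC(C)=O` gives 1.59 nM
compound 3 `COc1ccc(OCCCc2ccccc2)c(CCCNC(C)=O)c1` gives 72.2 nM

Compound 3 carries the highest number of the three, although compound 1 lies within the scatter of it. Compound 2 sits far below, as the step of a 45-fold higher number from compound 2 to compound 3 (1.66 log units; beyond the scatter) shows. The next compound is compound 4 `COc1ccc(OCc2ccccn2)c(CCCNC(C)=O)c1`, which differs from compound 3 by pyridin-2-yl in place of phenethyl on a saturated chain carbon bound to an oxygen on an aromatic ring. Among the compounds with values here, two measured steps bear on this. The step of a 29-fold lower number from compound 1 to compound 2 (1.46 log units; beyond the scatter) shows that ethyl in place of hydrogen on the aromatic oxygen brings a large fall in the number, and the step of a 45-fold higher number from compound 2 to compound 3 (1.66 log units; beyond the scatter) shows that lengthening that chain with a benzyl brings a large rise. Compound 4 keeps an aromatic ring on the chain but the chain itself is shorter than in compound 3, so a fall in the number, though a smaller one than either measured step, is expected: a 4.0-fold lower number from compound 3 to compound 4 (0.60 log units; beyond the scatter). For compound 4 the estimate is 18 nM, with a range from 4 nM to 80 nM.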

Compound 4, inhibition constant: 1.61 nM
Compound 4: middle estimate off by 11-fold (1.05 log units), on the high side, and the stated range ends above it.
By their numbers in this assay, from the lowest: compounds 2 and 4 (each within the scatter of the next); then compounds 1 and 3 (each within the scatter of the next).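

At this position a large aromatic group need not cost affinity: (pyridin-2-yl)methyl in place of hydrogen on the aromatic oxygen gives a 29-fold lower number from compound 1 to compound 4 (1.46 log units; beyond the scatter) and draws level with the ethyl group of compound 2, with a 1.0-fold higher number from compound 2 to compound 4 (0.01 log units; within the scatter) as the step between them. The high number of compound 3 is thus no general penalty for an aromatic ring on this chain: pyridin-2-yl in place of phenethyl gives a 45-fold lower number from compound 3 to compound 4 (1.65 log units; beyond the scatter) and removes the whole of that loss. No measurement shown here accounts for this.

The change alters the chain length and brings in a ring nitrogen at once, and the compounds shown do not separate the two. Phenyl on the same chain carbon would address that, and pyridin-3-yl or pyridin-4-yl would test where the ring nitrogen can sit.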